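The source may hold more compounds than are shown below. What is called first, only, known or untested is meant among the compounds shown, and "the series" means these compounds.

For the measured compounds named here, compound 1, `Cc1cnc(Nc2cc(N3C[C@@H]4C[C@H]3CN4C)cnc2F)nc1Nc1cccc(CO)c1`, is the only compound here with a number: in a functional assay on A549 cells (Homo sapiens) for antiproliferative activity, read by resazurin assay, with a stated time of 48 h (on this read-out higher numbers stand for weaker inhibition of growth and lower numbers for stronger inhibition of growth), compound 1 gives 253 nM. A close relative, compound 2, `Cc1cnc(Nc2cc(N3C[C@@H]4C[C@H]3CN4C)ccc2F)nc1Nc1cccc(CO)c1`, has no number to set beside it: in this assay compound 2 stands at "not determined" (no result reported). Compound 3, `Cc1cnc(Nc2cc(N3C[C@@H]4C[C@H]3CN4C)cnc2F)nc1N[C@H](C)C(C)C`, has not yet been tested. It differs from compound 1 in one place: 1,2-dimethylpropyl in place of 3-(hydroxymethyl)phenyl on a nitrogen on an aromatic ring. Going by the values given here, with no comparable step among measured compounds to lean on, a modest loss of growth inhibition is expected, so the step from compound 1 to compound 3 is estimated at a 2.6-fold higher number from compound 1 to compound 3 (0.41 log units; beyond the scatter), somewhat beyond the usual scatter. Compound 3 is therefore expected to give about 650 nM, within a range of 160 nM to 2600 nM.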

Compound 3, concentration for 50% growth inhibition: > 10000 nM
Compound 3: no number, only a limit; the forecaster's own chance of this, stated with the estimate: 5%; at least 15-fold (1.18 log units) between middle value and limit.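

Putting 1,2-dimethylpropyl in place of 3-(hydroxymethyl)phenyl on this nitrogen brings an at least 39-fold higher number from compound 1 to compound 3 (1.59 log units; beyond the scatter), so growth inhibition in this assay depends strongly on the group at this place. For compound 3 the value is a limit and not a number, so the true size of the step stays unknown: the limit of > 10000 nM in this assay, at which 1 of the 3 values shown sits.

The aromatic ring and its hydroxymethyl leave together in this one change, so the compounds shown do not tell which of the two counts. A plain phenyl group on the same nitrogen would separate them.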